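The compounds below may be only part of what the source reports. "The series", "measured", "known", "first", "only" and "open" are said of these compounds alone.

Three measured compounds share one core, each carrying two chlorophenyl groups and an amino group on it. Compound 1 `Nc1sc(-c2ccc(Cl)cc2)c(-c2ccc(Cl)cc2)c1C(=O)N1CCCC1` has a pyrrolidin-1-yl group on the carbonyl carbon, compound 2 `CC(C)(C)NC(=O)c1c(N)sc(-c2ccc(Cl)cc2)c1-c1ccc(Cl)cc1` a (tert-butyl)amino group there, and compound 3 `CCOC(=O)Nc1sc(-c2ccc(Cl)cc2)c(-c2ccc(Cl)cc2)c1C(=O)NC1CC1` a cyclopropylamino group together with an ethyl carbamate on the amino nitrogen. In a functional assay on PC-3 cells (Homo sapiens) for inhibition, read by sulforhodamine B assay, with a stated time of 72 h (a higher number here means a weaker inhibitor, a lower number a stronger inhibitor), compound 1 gives 6220 nM. In this assay compound 2 gives 15100 nM, and compound 3 gives 27600 nM. Among the measured compounds shown here, compound 2 thus stands second highest of the three numbers: compound 3 lies within the scatter of it, while compound 1 lies beyond the scatter below it, the step of a 2.4-fold higher number from compound 1 to compound 2 (0.39 log units; beyond the scatter) being the only single change measured at the carbonyl carbon.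

Compound 4 `Nc1sc(-c2ccc(Cl)cc2)c(-c2ccc(Cl)cc2)c1C(=O)NCc1ccccc1` differs from compound 2 in one place: benzyl in place of tert-butyl on an amide-type nitrogen. For the measured compounds named here, the only measured step that bears on this spot is the one from compound 1 to compound 2, and it was modest. Nothing measured shows a benzyl at that position, so the expectation for compound 4 is a step of about the same modest size or none beyond the scatter, in either direction. For compound 4 the estimated step is a 1.3-fold lower number from compound 2 to compound 4 (0.10 log units; within the scatter), giving an expected value of 12000 nM with a range from 5000 nM to 30000 nM.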

Compound 4, half-maximal inhibitory concentration: 31800 nM
Estimate against measurement, compound 4: 2.7-fold (0.42 log units) below; measured number above the stated range.
By their numbers in this assay, from the lowest: compound 1; then compounds 2, 3 and 4 (each within the scatter of the next, the first and the last beyond it).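

In this assay, benzyl in place of tert-butyl on the amide-type nitrogen gives a 2.1-fold higher number from compound 2 to compound 4 (0.32 log units; beyond the scatter), so the added aromatic ring brings no gain at this spot, and the number moves the other way by more than the usual scatter. Set against the pyrrolidin-1-yl group, benzylamino gives the larger step, a 5.1-fold higher number from compound 1 to compound 4 (0.71 log units; beyond the scatter), so both single changes measured at this carbonyl carbon, to compound 2 and to compound 4, lead to a higher number and none leads to a lower one. No measurement here explains why the benzyl group gives the higher number.

Because only three groups have been compared at this carbonyl carbon, the compounds shown leave open whether any other group could match or improve on pyrrolidin-1-yl, such as a piperidine or morpholine ring joined through its nitrogen. They also leave open how a small methyl group or a longer phenethyl chain on the amide-type nitrogen would compare with tert-butyl and benzyl.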